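The compounds below may be only part of what the source reports. "The series", "measured", "known", "first", "only" and "open" are said of these compounds alone.

Of the compounds shown here, three sharing the same core have been measured in an in vitro functional assay on 1321-N1 cells for agonist activity at Free fatty acid receptor 1 (Homo sapiens), read by fluorescence; a higher number here means that more compound is needed for the effect, a lower number that less compound is needed. Compound 1 `C#Cc1cccc(C#Cc2ccc(CCC(=O)O)cc2)c1` gives 155 nM. Compound 2 `Cc1cccc(C#Cc2ccc(CCC(=O)O)cc2)c1` gives 43.7 nM. Compound 3 `O=C(O)CCc1ccc(C#Cc2cccc(CO)c2)cc1` gives 891 nM, the highest of the three numbers; its nearest neighbour is compound 1, and the step of a 5.7-fold higher number from compound 1 to compound 3 (0.76 log units; beyond the scatter) is modest, while the step of a 20-fold higher number from compound 2 to compound 3 (1.31 log units; beyond the scatter) is large.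

Compound 4 `O=C(O)CCc1ccc(C#Cc2cccc(C(F)(F)F)c2)cc1` is not yet measured. It differs from compound 3 by trifluoromethyl in place of hydroxymethyl on an aromatic carbon. Of the measured steps, a 20-fold higher number from compound 2 to compound 3 (1.31 log units; beyond the scatter) bears most directly on this change: it introduces the hydroxy that compound 4 lacks, and it is the largest step seen here. The step of a 5.7-fold higher number from compound 1 to compound 3 (0.76 log units; beyond the scatter) points the same way, with hydroxymethyl again at the higher number. With the hydroxymethyl gone in compound 4, the expectation is a move toward the lower numbers of compound 1 and compound 2; yet the entering group is not a methyl, and whether compound 4 matches compound 2 or stops short is not settled by these data. Compound 4 is therefore expected to give 110 nM, within the range 30 nM to 400 nM. The expected step of an 8.1-fold lower number from compound 3 to compound 4 (0.91 log units; beyond the scatter) is closer in size to the step from hydroxymethyl to ethynyl than to the full step from hydroxymethyl to methyl.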

Compound 4, half-maximal effective concentration: 89.1 nM
Estimate against measurement, compound 4: 1.2-fold (0.09 log units) above, within the range that was stated.
By their numbers in this assay, from the lowest: compound 2; then compounds 4 and 1 (each within the scatter of the next); then compound 3.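

Taken together with the earlier steps, the change in this assay shows that the high number of compound 3 does not carry over to every other group tried at this place: a 10-fold lower number from compound 3 to compound 4 (1.00 log units; beyond the scatter) comes with a group that holds more heavy atoms than hydroxymethyl and has no hydrogen-bond donor or acceptor. So in this series the number does not simply rise with the heavy-atom count of the group, and hydroxymethyl stands apart from methyl, ethynyl and trifluoromethyl alike. Trifluoromethyl is still not equivalent to methyl, as a 2.0-fold higher number from compound 2 to compound 4 (0.31 log units; beyond the scatter) lies beyond the scatter, whereas a 1.7-fold lower number from compound 1 to compound 4 (0.24 log units; within the scatter) lies within it, so trifluoromethyl and ethynyl cannot be told apart here.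

No measurement at hand gives a reason why hydroxymethyl stands apart from the other three groups. From the compounds shown here alone, whether the oxygen-bearing hydroxymethyl is an isolated case also stays open, since a methoxymethyl, an aminomethyl or a carboxylic acid at this place could follow it or join the lower group, and the same four groups could rank differently elsewhere on the ring.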